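Working notes: from compound 2 to compound 3

This account rests on a few compounds, and the source may have more. Where it says the series, first, only, none or still open, it means among the compounds named here.

Compound 1 `CCN(CC)c1ccc(/C=C/C(=O)c2ccc(OC)c3c2OC(C)(C)C=C3)cc1`: 620 nM
Compound 2 `COc1ccccc1/C=C/C(=O)c1ccc(OC)c2c1OC(C)(C)C=C2`: > 10000 nM (a limit)

In a functional assay on HCT-116 cells (Homo sapiens) for antiproliferative activity, read by MTT assay, with a stated time of 24 h (on this read-out higher numbers stand for weaker inhibition and lower numbers for stronger inhibition), compound 1 gives 620 nM. Compound 2 stands only at a limit, not at a number: the limit of > 10000 nM in this assay, at which 1 of the 2 values shown sits.

Compound 3 `COc1ccc(C(=O)/C=C/c2ccc(O)cc2)c2c1C=CC(C)(C)O2` carries one change from compound 2: 4-hydroxyphenyl in place of 2-methoxyphenyl on a double-bonded chain carbon bound to a double-bonded chain carbon. In words, this is 4-hydroxyphenyl in place of 2-methoxyphenyl on a double-bonded chain carbon bound to a double-bonded chain carbon. Within the data shown here, no measured step covers this change. Compound 1, at 620 nM, shows that the shared core can give a measurable value, so a moderate step toward stronger inhibition is expected in this assay. The expected size is an at least 3.3-fold lower number from compound 2 to compound 3 (0.52 log units; beyond the scatter), an estimate that is loose. Compound 3 is estimated at 3000 nM, with an expected range of 900 nM to 10000 nM.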

Compound 3, half-maximal inhibitory concentration: > 10000 nM
Compound 3 was reported as a limit (the forecaster's own chance of this, stated with the estimate: 25%); at least 3.3-fold (0.52 log units) between middle value and limit.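

Compound 3 stands at a limit, not at a number, as compound 2 does. Set against compound 1, hydroxy in place of diethylamino on an aromatic carbon gives an at least 16-fold higher number from compound 1 to compound 3 (1.20 log units; beyond the scatter) in this assay, so on the shared core a measurable value is kept with diethylamino and lost with hydroxy. The change from 2-methoxyphenyl to 4-hydroxyphenyl on a double-bonded chain carbon bound to a double-bonded chain carbon cannot be read, and neither group separates itself from the other in this series: the limit of > 10000 nM in this assay, at which 2 of the 3 values shown sit.

Open, from the compounds shown here alone, is whether a smaller amine such as dimethylamino, on an aromatic carbon, would also give a measurable value. Also open, going by these compounds, is how far compound 2 and compound 3 differ beyond the limit they share.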